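Swapping the isomeric nitrile ring on the amine nitrogen

The source may report more compounds than this note shows. Statements on the series, on what has been measured and on what is new or still open speak of the compounds shown alone.

Measured in a physicochemical assay for lipophilicity, read by HPLC, measured as chromatographic lipophilicity, at pH 7.4; a higher number here means a more lipophilic compound, a lower number a more polar compound:
- Compound 1 `N#Cc1ccc(N2CCC(C(=O)N3N=CC[C@H]3c3cc(F)cc(F)c3)CC2)nn1`: 4.8
- Compound 2 `O=C(c1cccnc1)N1N=CCC1c1ccccc1`: 2.7

Compound 1 stands highest of the two numbers, and its gap to compound 2 lies beyond the scatter. Going by the values given here, the two differ in more than one place, and no measured pair differs in one place only. The size of the next step therefore has no direct measured guide.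

Compound 3 `N#Cc1cnc(N2CCC(C(=O)N3N=CC[C@H]3c3cc(F)cc(F)c3)CC2)cn1` keeps the core of compound 1 and changes one group, on an amine nitrogen in a ring: a group of 8 heavy atoms (5 carbon, 3 nitrogen; one six-membered aromatic ring with 2 hetero atoms) in place of a group of 8 heavy atoms (5 carbon, 3 nitrogen; one six-membered aromatic ring with 2 hetero atoms), on an amine nitrogen in a ring. The 5-cyanopyrazin-2-yl group enters, and the two compounds have the same atoms, joined differently.

In this assay a small upward step is expected, close to the scatter in size. The estimated move is a number 0.20 log units higher from compound 1 to compound 3 (within the scatter). For compound 3 the expected value is 5, with an estimated range of 4.6 to 5.4.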

Compound 3, distribution coefficient: 5.2
The estimate for compound 3 lay 0.20 log units below the measured number; the range from low to high includes it.
By their numbers in this assay, from the lowest: compound 2; then compound 1; then compound 3.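

In this assay, going by these compounds alone, this is the first comparison that differs in one place only: the group on the amine nitrogen becomes 5-cyanopyrazin-2-yl, with the same atoms and the same counts of hydrogen-bond donors and acceptors, and the reading is a number 0.40 log units higher from compound 1 to compound 3 (beyond the scatter) in a step of modest size. At this position the read-out therefore responds to how the same atoms are joined, not only to which atoms are present. No accompanying measurement bears on what lies behind this step.

From the compounds shown here alone, with a single pair to read, it remains open whether the same swap gives a similar step on another core. Also open, going by these compounds, is how the reading moves with a plain phenyl ring, or with a carboxylic acid in place of the nitrile, on that amine nitrogen.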